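This account rests on a few compounds, and the source may have more. Where it says the series, first, only, none or still open, it means among the compounds named here.

Compound 1 `O=C(CSc1nc(Nc2ccccc2)c2ccccc2n1)Nc1cccc(Cl)c1` gives 14300 nM in a functional assay on MGC-803 cells (Homo sapiens) for inhibition, read by MTT assay, with a stated time of 72 h; a lower number here means a stronger inhibitor, a higher number a weaker inhibitor.
Compound 2 `COc1cccc(NC(=O)CSc2nc(Nc3ccccc3)c3ccccc3n2)c1` gives 10000 nM in this assay.

Within the data shown here, only these two compounds have been measured, and their numbers sit close together: the step of a 1.4-fold lower number from compound 1 to compound 2 (0.16 log units; within the scatter) stays inside the scatter of repeated measurements, so compound 2 cannot be called the stronger of the pair on this evidence, only one of two compounds that behave alike.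

Compound 3 `O=C(CSc1nc(Nc2ccccc2)c2ccccc2n1)Nc1ccc([N+](=O)[O-])cc1` is the next compound, and it has not yet been measured in this assay. It differs from compound 2 by 4-nitrophenyl in place of 3-methoxyphenyl on an amide-type nitrogen. Among the measured compounds shown here, the one measured step that bears on this change is the exchange on the same ring between compound 1 and compound 2, a 1.4-fold lower number from compound 1 to compound 2 (0.16 log units; within the scatter), which is within the scatter. For the measured compounds named here, no measured compound carries a 4-nitrophenyl group, so there is no direct guide for it. For compound 3 the expectation is therefore a step of a 1.2-fold higher number from compound 2 to compound 3 (0.08 log units; within the scatter), which is to say no change beyond the scatter. The estimate for compound 3 in this assay is 12000 nM, with a range from 4000 nM to 40000 nM.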

Compound 3, half-maximal inhibitory concentration: > 50000 nM
Compound 3: only a limit was reported; the forecaster's own chance of this, stated with the estimate: 10%; middle value at least 4.1-fold (0.61 log units) away from the limit.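

In this assay compound 3 gives > 50000 nM, which is a limit of the assay and not an exact number. Even so, the steps can be read, and they show that this position on the amide-type nitrogen is not indifferent to what it carries: the exchange of the aromatic group gives an at least 5.0-fold higher number from compound 2 to compound 3 (0.69 log units; beyond the scatter) and an at least 3.4-fold higher number from compound 1 to compound 3 (0.54 log units; beyond the scatter), whereas the only earlier step, a 1.4-fold lower number from compound 1 to compound 2 (0.16 log units; within the scatter), stayed within the scatter and showed no difference between the 3-chlorophenyl and 3-methoxyphenyl groups. Both new steps give only a smallest size for the change, and compound 3 is the one compound here that reaches the limit of the assay: the limit of > 50000 nM in this assay, at which 1 of the 3 values shown sits.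

The 4-nitrophenyl group differs from the other two aromatic groups both in its substituent and in where that substituent sits on the ring, so these compounds cannot tell which of the two matters. A 3-nitrophenyl or a 4-methoxyphenyl group on the same nitrogen would separate the two, and a 4-aminophenyl group or a ring bearing a carboxylic acid would show how far the weakening extends to other substituents.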